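Swapping the amide substituent of compound 2

A few compounds are considered here, and "the series" means these few. Any claim that something is new, unique, unknown or untested is made for them only; others in the source may bear on it.

Of the compounds shown here, three have been tested in a functional assay on L6 cells (Rattus norvegicus) for inhibition; a higher number here means a weaker inhibitor, a lower number a stronger inhibitor. Compound 1 `Cc1ccc(CNC(=O)c2nn(-c3ccc(F)cc3)c(CC[C@@H](O)C[C@@H](O)CC(=O)O)c2C(C)C)cc1` gives 800 nM, compound 2 `Cc1ccc(CN(C)C(=O)c2nn(-c3ccc(F)cc3)c(OC[C@@H](O)C[C@@H](O)CC(=O)O)c2C(C)C)cc1` gives 1250 nM, and compound 3 `CC(C)c1c(C(=O)N2CCC[C@H](N3CCC4C=CC=CC4C3)C2)nn(-c2ccc(F)cc2)c1CC[C@@H](O)C[C@@H](O)CC(=O)O` gives 1720 nM. The number for compound 2 sits between those of compound 1 and compound 3, but both gaps fall within the usual scatter of repeated measurements, so the three are not separable. Compound 4 `COc1cccc(CNC(=O)c2nn(-c3ccc(F)cc3)c(OC[C@@H](O)C[C@@H](O)CC(=O)O)c2C(C)C)c1` differs from compound 2 by (3-methoxybenzyl)amino in place of methyl(4-methylbenzyl)amino on a carbonyl carbon. Going by the values given here, no measured pair shows this change, so the step from compound 2 to compound 4 is expected to be small, with no direction beyond the scatter, a 1.3-fold lower number from compound 2 to compound 4 (0.10 log units; within the scatter). Compound 4 is therefore estimated at 1000 nM in this assay, within a range of 400 nM to 3000 nM.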

Compound 4, half-maximal inhibitory concentration: 8750 nM
Estimate against measurement, compound 4: 8.8-fold (0.94 log units) below; the measured number lies above the stated range.
By their numbers in this assay, from the lowest: compounds 1, 2 and 3 (each within the scatter of the next, the first and the last beyond it); then compound 4.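

Going by these compounds alone, the substituent on this carbonyl carbon matters: in this assay the swap gives a 7.0-fold higher number from compound 2 to compound 4 (0.85 log units; beyond the scatter) and this step lies beyond the scatter, something the earlier compounds, with no pair differing in one place, could not show. The swap changes more than one feature, as the amide gains a hydrogen in place of a methyl while the ring's 4-methyl gives way to a 3-methoxy group. No measurement here explains the step. Which feature carries the step stays open. Methyl(3-methoxybenzyl)amino on the same carbonyl carbon would separate the amide hydrogen from the ring change.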